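A few compounds are considered here, and "the series" means these few. Any claim that something is new, unique, unknown or untested is made for them only; others in the source may bear on it.

Working notes on the series. In a functional assay on MCF7 cells (Homo sapiens) for antiproliferative activity, read by MTT assay, with a stated time of 72 h (on this read-out lower numbers stand for stronger inhibition and higher numbers for weaker inhibition), compound 1 `O=C(COc1ccc(C(=O)/C=C/c2ccc(Cl)cc2Cl)cc1)N[C@H]1CCOC1=O` gives 34400 nM. Compound 2 `O=C(COc1ccc(C(=O)/C=C/c2cccc(Br)c2)cc1)N[C@H]1CCOC1=O` shares the core of compound 1 and carries a 3-bromophenyl on the double-bonded chain carbon in place of the 2,4-dichlorophenyl; in this assay compound 2 gives 28300 nM. The step of a 1.2-fold lower number from compound 1 to compound 2 (0.08 log units; within the scatter) is within the scatter, so the two measured numbers stand together and neither compound can be set apart from the other on these data.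

Compound 3 `O=C(COc1ccc(C(=O)/C=C/c2cccc([N+](=O)[O-])c2)cc1)N[C@H]1CCOC1=O` differs from compound 2 by nitro in place of bromo on an aromatic carbon. Among the measured compounds shown here, the only measured step in the set, a 1.2-fold lower number from compound 1 to compound 2 (0.08 log units; within the scatter), exchanges substituents on the same aromatic ring and gave no movement beyond the scatter; no measured step in this assay involves a nitro group, and none tests an exchange of bromo on this ring. On that basis no step beyond the scatter is expected in this assay for the change from compound 2. The expected step is a 1.1-fold higher number from compound 2 to compound 3 (0.03 log units; within the scatter). Compound 3 is therefore estimated at 30000 nM, with a range from 12000 nM to 75000 nM.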

Compound 3, half-maximal inhibitory concentration: > 64000 nM
Compound 3 was reported as a limit; the forecaster's own chance of this, stated with the estimate: 5%; middle value at least 2.1-fold (0.32 log units) from the limit.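

In this assay, the result for compound 3 is a limit and not a number: the limit of > 64000 nM in this assay, at which 1 of the 3 values shown sits.

Even so, the exchange at this aromatic carbon, meta to a large group, gives an at least 2.2-fold higher number from compound 2 to compound 3 (0.35 log units; beyond the scatter), the first step in the set that lies beyond the scatter, so this position is not indifferent to the substituent it carries, which the earlier pair of compounds could not show. As far as these compounds go, the second new step is less firm, an at least 1.8-fold higher number from compound 1 to compound 3 (0.26 log units; that floor lies within the scatter), so on this floor the two compounds in that step cannot be set apart, and the full size of both new steps remains unknown.

The compounds shown leave open how far the number for the 3-nitrophenyl compound really lies from those of the other two, and whether the change is particular to nitro or would also appear with other groups in the same place, such as an amine or a carboxylic acid. They also leave open whether nitro would give the same step at another place on this ring, since only one position carries it here.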